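Shifting the allyloxy group on compound 3

A few compounds are considered here, and "the series" means these few. Any claim that something is new, unique, unknown or untested is made for them only; others in the source may bear on it.

Measured in a functional assay on SK-OV-3 cells (Homo sapiens) for inhibition, read by MTT assay, with a stated time of 72 h; on this read-out higher numbers stand for weaker inhibition of growth and lower numbers for stronger inhibition of growth:
- compound 1 `O=C1CC(N2C(=O)CSC2=S)C(=O)N1c1ccc(Cl)cc1`: > 100000 nM (a limit)
- compound 2 `O=C1CC(N2C(=O)/C(=C/C(Cl)=C/c3ccc([N+](=O)[O-])cc3)SC2=S)C(=O)N1c1ccc(Cl)cc1`: 65900 nM
- compound 3 `C=CCOc1ccccc1/C=C1\SC(=S)N(C2CC(=O)N(c3ccc(Cl)cc3)C2=O)C1=O`: > 100000 nM (a limit)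

Compound 3 stands at > 100000 nM, which is a limit and not a number. The wider picture is thin, with the limit of > 100000 nM in this assay, at which 2 of the 3 values shown sit. For the measured compounds named here, compound 2 reads 65900 nM and is the only compound here with a true number.

Compound 4 `C=CCOc1cccc(/C=C2\SC(=S)N(C3CC(=O)N(c4ccc(Cl)cc4)C3=O)C2=O)c1` has 3-(allyloxy)phenyl in place of 2-(allyloxy)phenyl on a double-bonded chain carbon bound to a double-bonded ring carbon. The two have the same atoms, joined differently. Going by the values given here, no measured pair shows what such a change does. No step beyond the scatter is therefore expected in this assay, and the reading may well be a limit again. Should a number appear, it is expected in the region of compound 2 at 65900 nM.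

The expected step is an at least 1.1-fold lower number from compound 3 to compound 4 (0.04 log units; that floor lies within the scatter).

Compound 4 is estimated at 90000 nM, with an expected range of 40000 nM to 200000 nM.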

Compound 4, concentration for 50% growth inhibition: > 100000 nM
Compound 4: only a limit was reported; the forecaster's own chance of this, stated with the estimate: 65%; at least 1.1-fold (0.04 log units) between middle value and limit.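

Compound 3 and compound 4 both read as limits and not as numbers, so no step can be read between them: the limit of > 100000 nM in this assay, at which 3 of the 4 values shown sit.

In this assay the compounds shown leave open whether 3-(allyloxy)phenyl and 2-(allyloxy)phenyl differ at all.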